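Bromo in place of methyl on an aromatic carbon

The source may report more compounds than this note shows. Statements on the series, on what has been measured and on what is new or still open speak of the compounds shown alone.

Measured so far in a functional assay on T47D cells (Homo sapiens) for inhibition, read by sulforhodamine B assay, with a stated time of 48 h; a lower number here means a stronger inhibitor of growth, a higher number a weaker inhibitor of growth:
compound 1 `COC(=O)[C@@]1(C)CCC=C2[C@@H]1CC[C@@H](C)[C@]2(C)Cc1c[nH]c2c(C)cccc12` gives 18000 nM
compound 2 `COC(=O)[C@@]1(C)CC[C@@H]2C3=C1CC[C@@H](C)[C@]3(C)C[C@@H]1c3ccccc3N[C@H]21` gives 35000 nM
compound 3 `COC(=O)[C@@]1(C)CC[C@@H]2C3=C1CC[C@@H](C)[C@]3(C)C[C@@H]1c3cccc(C)c3N[C@H]21` gives 29000 nM

Compound 3 has the second highest of the three numbers in this assay; its gaps to compound 2 and to compound 1 are both within the scatter, so the three compounds sit as one cluster. Compound 4 `COC(=O)[C@@]1(C)CC[C@@H]2C3=C1CC[C@@H](C)[C@]3(C)C[C@@H]1c3cccc(Br)c3N[C@H]21` differs from compound 3 by bromo in place of methyl on an aromatic carbon. For the measured compounds named here, the only measured step at this position is a 1.2-fold lower number from compound 2 to compound 3 (0.08 log units; within the scatter), which shows that adding a methyl there leaves the number where it was. Going by the values given here, no bromo analogue has been measured in this assay. For compound 4 the change is therefore expected to stay within the scatter, a 1.2-fold lower number from compound 3 to compound 4 (0.06 log units; within the scatter). The estimate for compound 4 in this assay is 25000 nM, with a range of 10000 nM to 60000 nM.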

Compound 4, concentration for 50% growth inhibition: 37000 nM
The estimate for compound 4 lay 1.5-fold (0.17 log units) below the measured number; measured number inside the range.
By their numbers in this assay, from the lowest: compounds 1, 3, 2 and 4 (each within the scatter of the next, the first and the last beyond it).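

In this assay bromo on this aromatic carbon gives a 1.3-fold higher number from compound 3 to compound 4 (0.11 log units; within the scatter) and, measured against the unsubstituted compound, a 1.1-fold higher number from compound 2 to compound 4 (0.02 log units; within the scatter). Both steps stay within the scatter, so a halogen here behaves like methyl and hydrogen, and the three substituents read as one level at this position. Nothing available explains this flat response. Still open, from the compounds shown here alone, is whether an amine or a carboxylic acid on this carbon would move the number beyond the scatter. Also open, going by these compounds, is whether any substituent at this place can give a stronger inhibitor of growth.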